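Swapping the aryl urea substituent in a quinoline series

A few compounds are considered here, and "the series" means these few. Any claim that something is new, unique, unknown or untested is made for them only; others in the source may bear on it.

Measured compounds:
Compound 1, `COc1cc(NC(C)CCCNC(=O)Nc2ccc(C(F)(F)F)cc2)c2ncccc2c1`, 14000 nM
Compound 2, `COc1cc(NC(C)CCCNC(=O)NNC(=O)Nc2cccc(C(F)(F)F)c2)c2ncccc2c1`, 6900 nM

Both compounds were tested in a functional assay on CCRF-CEM cells (Homo sapiens) for inhibition, read by MTT assay, with a stated time of 72 h; a higher number here means a weaker inhibitor, a lower number a stronger inhibitor. Compound 1 gives the higher of the two numbers; compound 2 is the nearer and only neighbour, and its lower number lies beyond the usual scatter, so compound 1 is the weaker inhibitor of the pair.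

Compound 3, `COc1cc(NC(C)CCCNC(=O)Nc2cccc(Cl)c2)c2ncccc2c1`, has not been measured. It differs from compound 1 in one place: 3-chlorophenyl in place of 4-(trifluoromethyl)phenyl on an amide-type nitrogen. The urea linkage and the shared core are unchanged. Going by the values given here, no measured pair in this set shows the effect of such an exchange, so the direction of the step is not anchored by data, and an estimate can rest only on the value of compound 1.

Compound 3 is expected to give about 12000 nM in this assay, with a range from 4000 nM to 40000 nM. The step that this expectation implies, a 1.2-fold lower number from compound 1 to compound 3 (0.07 log units; within the scatter), is estimated to stay within the usual scatter, with no confident direction.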

Compound 3, half-maximal inhibitory concentration: 22000 nM
Compound 3: the middle estimate sits 1.8-fold (0.26 log units) below what was measured, within the range that was stated.
By their numbers in this assay, from the lowest: compound 2; then compounds 1 and 3 (each within the scatter of the next).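

In this assay, placing 3-chlorophenyl in place of 4-(trifluoromethyl)phenyl on the amide-type nitrogen, whose other neighbour is the carbonyl carbon, gives a 1.6-fold higher number from compound 1 to compound 3 (0.20 log units; within the scatter). Going by these compounds alone, this is the first single-place change in the set, and it shows that this exchange, in which the entering aryl group has fewer heavy atoms than the one that leaves, does not separate the two compounds beyond the usual scatter, with the urea linkage and the shared core held constant. No measured property or other supporting data bear on this result, so the close agreement of the two numbers stands without an explanation.

Within the data shown here, the single step alters both the substituent and the number in the group's name, so it cannot show what either alteration does alone, and it speaks for this one pair only. From the compounds shown here alone, whether a plain phenyl, or a phenyl carrying a carboxylic acid or an amine, on this same nitrogen would move the number beyond the scatter remains open.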